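The source may hold more compounds than are shown below. What is called first, only, known or untested is meant among the compounds shown, and "the series" means these compounds.

Compound 1 `CC(C)c1cccc(C2CNCC2C(=O)Nc2cc3cc[nH]c(=O)c3cc2Cl)c1` — "not determined" (no result reported) in a functional assay on aorta (Rattus norvegicus) for inhibition; on this read-out higher numbers stand for weaker inhibition and lower numbers for stronger inhibition.
Compound 2 `O=C(Nc1cc2cc[nH]c(=O)c2cc1Cl)C1CNCC1c1ccc(F)cc1` — 160 nM.

Going by the values given here, compound 2 stands alone: it is the only compound with a number on this assay, while compound 1 has no reported value, so there is nothing to set beside it. On this assay compound 2 gives 160 nM. Compound 3 `O=C(Nc1cc2cc[nH]c(=O)c2cc1Cl)C1CNCC1c1ccccn1` differs from compound 2 in a single place: pyridin-2-yl in place of 4-fluorophenyl on a saturated ring carbon. Among the compounds with values here, no step between two measured compounds is available to anchor this change, and the expectation therefore rests on compound 2 alone. A modest shift toward weaker inhibition is expected, possibly no larger than the usual scatter, and it is written as a 1.9-fold higher number from compound 2 to compound 3 (0.27 log units; within the scatter). Compound 3 is estimated at 300 nM, with a likely range from 80 nM to 1200 nM.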

Compound 3, half-maximal inhibitory concentration: 210 nM
The estimate for compound 3 lay 1.4-fold (0.15 log units) above the measured number; measured number inside the range.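

In this assay, pyridin-2-yl in place of 4-fluorophenyl on the saturated ring carbon gives a 1.3-fold higher number from compound 2 to compound 3 (0.12 log units; within the scatter), so the two compounds cannot be told apart on this read-out. This first readable step at this position shows that a six-membered aromatic ring with one hetero atom and one hydrogen-bond acceptor can replace the carbon-only ring bearing fluorine with no difference beyond the scatter. Nothing available explains this result.

Going by these compounds, one step at one position cannot show how far this tolerance extends, so it remains open whether a pyridin-3-yl or pyridin-4-yl ring would read the same way. On these data alone, it is equally open whether the position would tolerate a ring carrying a carboxylic acid, or a non-aromatic group such as a cyclohexyl ring.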